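Shifting a methanesulfonamide to an amide on two cores

The compounds below may be only part of what the source reports. "The series", "measured", "known", "first", "only" and "open" are said of these compounds alone.

Three compounds sharing a hydroxynaphthalene-bearing scaffold were measured in an assay for binding affinity to 17-beta-hydroxysteroid dehydrogenase type 1 (Homo sapiens), with a stated time of 20 min, tested at 1 uM; a lower number here means less inhibition, a higher number more inhibition at the concentration tested (going by the name of the read-out). Compound 1 `CS(=O)(=O)Nc1ccc(-c2ccc3c(O)cccc3c2)cc1` gives 52%. Compound 2 `CS(=O)(=O)Nc1cccc(-c2ccc3c(O)cccc3c2)c1` gives 19%, a number well below that of compound 1; the difference between the two cores is not broken down here. For compound 3 `CNC(=O)c1ccc(-c2ccc3c(O)cccc3c2)cc1` the read-out is a limit of the assay, < 10%, as noted in the limit of < 10% in this assay, at which 1 of the 3 values shown sits.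

From compound 1 to compound 3 the change is methylcarbamoyl in place of methanesulfonamido on an aromatic carbon, and the step is a number at least 42 percentage points lower from compound 1 to compound 3 (beyond the scatter). Compound 4 `CNC(=O)c1cccc(-c2ccc3c(O)cccc3c2)c1` is not yet measured. It differs from compound 2 by methylcarbamoyl in place of methanesulfonamido on an aromatic carbon, the same kind of change, the place being meta to a large group rather than para to a large group.

Because compound 2 starts at 19% and the earlier change was a number at least 42 percentage points lower from compound 1 to compound 3 (beyond the scatter), the expected step in this assay is a number 13 percentage points lower from compound 2 to compound 4 (beyond the scatter). The estimate for compound 4 in this assay is 6%, with a range from 0% to 15%, most likely reported only as a limit.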

Compound 4, a percentage reported as inhibition, at one concentration (the size of the read-out at that concentration, not a potency): < 10%
Compound 4: no number, only a limit; the forecaster's own chance of this, stated with the estimate: 70%; the middle value lies beyond the limit too.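

In this assay compound 4 gives < 10%, which is a limit of the assay and not a number. Putting methylcarbamoyl in place of methanesulfonamido on this second core gives a number at least 9 percentage points lower from compound 2 to compound 4 (that floor lies within the scatter), so the result fits the drop seen on the first core but does not by itself establish a drop here. Set side by side, the two results show that the change gave no higher read-out on either core, but they do not show that it carries over with the same size: the same change on two cores in this assay, a number at least 42 percentage points lower (beyond the scatter) from compound 1 to compound 3 and a number at least 9 percentage points lower (that floor lies within the scatter) from compound 2 to compound 4; the limit leaves it open whether they differ

As far as these compounds go, the true size of the step on each core stays open, since both compounds with the methylcarbamoyl group end at a limit: the limit of < 10% in this assay, at which 2 of the 4 values shown sit. Also open is how other groups in the same place would behave, such as a carboxylic acid, an amine or a longer chain on the amide nitrogen.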